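Acetyl in Place of Acetamido: What Compound 4 May Show

This account rests on a few compounds, and the source may have more. Where it says the series, first, only, none or still open, it means among the compounds named here.

Compound 1, `C[S+]([O-])c1ccc(CNC(=O)c2ccc(C(C)(C)C)cc2)cc1`: 1300 nM in an assay on HeLa cells with Bile acid receptor (Homo sapiens) as the target, read by a luciferase reporter, with a stated time of 24 h; a lower number here means that less compound is needed, a higher number that more compound is needed for the effect
Compound 2, `CSc1ccc(CNC(=O)c2ccc(C(C)(C)C)cc2)cc1`: 100 nM
Compound 3, `CC(=O)Nc1ccc(CNC(=O)c2ccc(C(C)(C)C)cc2)cc1`: 2900 nM

Compound 3 stands highest of the three in this assay. Its nearest neighbour is compound 1, with a 2.2-fold higher number from compound 1 to compound 3 (0.35 log units; beyond the scatter); the furthest is compound 2, with a 29-fold higher number from compound 2 to compound 3 (1.46 log units; beyond the scatter).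

Compound 4, `CC(=O)c1ccc(CNC(=O)c2ccc(C(C)(C)C)cc2)cc1`, differs from compound 3 by acetyl in place of acetamido on an aromatic carbon. The acetyl that enters keeps one hydrogen-bond acceptor and carries no hydrogen-bond donor, whereas the acetamido that leaves carried one of each.

Among the compounds with values here, two measured steps bear on this change. The step of a 29-fold higher number from compound 2 to compound 3 (1.46 log units; beyond the scatter) is large, and the step of a 2.2-fold higher number from compound 1 to compound 3 (0.35 log units; beyond the scatter) is modest; both show that the acetamido of compound 3 gives the highest number among the three substituents tried at this carbon. Within the data shown here, no measured step removes only a donor while keeping an acceptor, so the direction for compound 4 is uncertain. Weighing the modest step from compound 1 more than the large step from compound 2, compound 4 is expected to show a 2.4-fold lower number from compound 3 to compound 4 (0.38 log units; beyond the scatter). The estimate for compound 4 is 1200 nM, with a range of 300 nM to 4500 nM.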

Compound 4, half-maximal effective concentration: 100 nM
Estimate against measurement, compound 4: 12-fold (1.08 log units) above; the measured number lies below the stated range.
By their numbers in this assay, from the lowest: compounds 2 and 4 (each within the scatter of the next); then compound 1; then compound 3.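

In this assay, acetyl in place of acetamido on this aromatic carbon gives a 29-fold lower number from compound 3 to compound 4 (1.46 log units; beyond the scatter), which shows that a group with a hydrogen-bond acceptor and no hydrogen-bond donor can carry a low number here. Set against methylsulfanyl, acetyl gives no change at the digits printed from compound 2 to compound 4 (within the scatter), and set against the oxygen-bearing group of compound 1, it gives a 13-fold lower number from compound 1 to compound 4 (1.11 log units; beyond the scatter), so an oxygen in the group at this carbon does not by itself go with a high number. Nothing measured here explains these shifts.

From the compounds shown here alone, whether the amide hydrogen alone sets compound 3 apart remains open. Going by these compounds, it is also open whether a low number would hold with a nitrile, a methyl ester, a methylamino group or a longer acyl chain such as propanoyl at this carbon.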